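The source may report more compounds than this note shows. Statements on the series, on what has been measured and on what is new or still open speak of the compounds shown alone.

Compound 1, `COc1ccc(-c2cc(C)c(Nc3ccnc(Nc4ccc(C#N)cc4)n3)c(C)c2)cc1`, gives 2890 nM in an ADME assay on MT4 cells (Homo sapiens) for cytotoxicity, read by MTT assay, with a stated time of 4 days; on this read-out lower numbers stand for higher toxicity in this test and higher numbers for lower toxicity in this test. Compound 2, `Cc1cc(-c2cccc(Cl)c2)cc(C)c1Nc1ccnc(Nc2ccc(C#N)cc2)n1`, gives 2160 nM in this assay.

On these two numbers compound 2 and compound 1 lie within the scatter of each other, as a 1.3-fold lower number from compound 1 to compound 2 (0.13 log units; within the scatter) shows; no real order between them can be claimed. Compound 3, `Cc1cccc(-c2cc(C)c(Nc3ccnc(Nc4ccc(C#N)cc4)n3)c(C)c2)c1`, differs from compound 2 by methyl in place of chloro on an aromatic carbon, sitting on an aromatic carbon of a six-membered aromatic ring of carbon only, meta to a large group; read one bond further out, 3-chlorophenyl becomes 3-methylphenyl. Among the measured compounds shown here, the only measured step that bears on this is the one that also reworked this same ring, a 1.3-fold lower number from compound 1 to compound 2 (0.13 log units; within the scatter), and it stayed inside the scatter. A swap of one small group for another on that ring is therefore expected to move this assay little, if at all, so the expected step is a 1.1-fold higher number from compound 2 to compound 3 (0.03 log units; within the scatter). Compound 3 is estimated at 2300 nM, within 1000 nM to 5200 nM.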

Compound 3, half-maximal cytotoxic concentration: 3670 nM
Estimate against measurement, compound 3: 1.6-fold (0.20 log units) below; measured number inside the range.
By their numbers in this assay, from the lowest: compounds 2, 1 and 3 (each within the scatter of the next).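

Chloro and methyl on this ring cannot be told apart in this assay: the change gives a 1.7-fold higher number from compound 2 to compound 3 (0.23 log units; within the scatter), so this one-atom swap, at the place meta to a large group, moves the number no further than repeated measurements would. The wider change of the whole ring substituent, from 4-methoxyphenyl to 3-methylphenyl, gives a 1.3-fold higher number from compound 1 to compound 3 (0.10 log units; within the scatter) and likewise stays inside the scatter, so all three of these outer rings give readings that cannot be separated. No measurement here explains why these numbers stay so close.

Still open, going by these compounds, is whether a group of a different kind at this place, such as an amine or a carboxylic acid, would shift the number beyond the scatter. A longer chain, such as propyl, poses the same question.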